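A few compounds are considered here, and "the series" means these few. Any claim that something is new, unique, unknown or untested is made for them only; others in the source may bear on it.

Compound 1 `CC(=N)N1CCC(Oc2ccc3ncn(Cc4ccc5ccc(C(=N)N)cc5c4)c3c2)CC1`, compound 2 `CC(=N)N1CCC(Oc2ccc3nc(C(C)C)n(Cc4ccc5ccc(C(=N)N)cc5c4)c3c2)CC1` and compound 3 `CCCc1nc2ccc(OC3CCN(C(C)=N)CC3)cc2n1Cc1ccc2ccc(C(=N)N)cc2c1` share one core. In an assay on isolated protein for inhibition of serine protease 1 (Bos taurus) (on this read-out lower numbers stand for stronger inhibition and higher numbers for weaker inhibition), compound 1 gives 50 nM, compound 2 gives 5.7 nM and compound 3 gives 6.8 nM. Compound 3 thus stands closest to compound 2 and far from compound 1. Compound 4 `CCC(C)c1nc2ccc(OC3CCN(C(C)=N)CC3)cc2n1Cc1ccc2ccc(C(=N)N)cc2c1` differs from compound 3 by methyl in place of hydrogen on a saturated chain carbon bound to an aromatic carbon and a saturated chain carbon. Of the measured steps, an 8.8-fold lower number from compound 1 to compound 2 (0.94 log units; beyond the scatter) and a 7.4-fold lower number from compound 1 to compound 3 (0.87 log units; beyond the scatter) show that adding a small alkyl group at that aromatic carbon helped, while a 1.2-fold higher number from compound 2 to compound 3 (0.08 log units; within the scatter) shows that its shape hardly mattered. For compound 4 a step of about a 1.0-fold lower number from compound 3 to compound 4 (0.02 log units; within the scatter) is therefore expected, that is, none beyond the scatter. In this assay compound 4 is estimated at 6.5 nM, within 2.5 nM to 16 nM.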

Compound 4, inhibition constant: 10 nM
Estimate against measurement, compound 4: 1.5-fold (0.19 log units) below; the measured number falls inside the stated range.
By their numbers in this assay, from the lowest: compounds 2, 3 and 4 (each within the scatter of the next); then compound 1.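

In this assay sec-butyl on the aromatic carbon keeps the gain over hydrogen, with a 5.0-fold lower number from compound 1 to compound 4 (0.70 log units; beyond the scatter) as the step. The added methyl does not set sec-butyl apart from propyl, with a 1.5-fold higher number from compound 3 to compound 4 (0.17 log units; within the scatter) as the step, or from isopropyl, with a 1.8-fold higher number from compound 2 to compound 4 (0.24 log units; within the scatter) as the step, so these three alkyl groups cannot be told apart here. No measurement at hand offers an explanation for this flat result. Still open, as far as these compounds go, is whether a longer chain such as hexyl, or an alkyl chain ending in an amine or a carboxylic acid, would keep this gain.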